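The source may hold more compounds than are shown below. What is called first, only, known or untested is meant among the compounds shown, and "the series" means these compounds.

Of the compounds shown here, two with a shared core have been measured. Compound 1 `CC(C)NC(=O)c1ccc2cc(C(O)(c3c[nH]cn3)C(C)C)ccc2c1` gives 12 nM in an assay on microsomes from Testis (strain Sprague-Dawley) for inhibition of steroid 17-alpha-hydroxylase/17,20 lyase (Rattus norvegicus) (on this read-out higher numbers stand for weaker inhibition and lower numbers for stronger inhibition), and compound 2 `CC(=O)c1ccc2cc(C(O)(c3c[nH]cn3)C(C)C)ccc2c1` gives 14 nM in this assay. Of the two numbers, compound 2 has the higher one, but the step of a 1.2-fold higher number from compound 1 to compound 2 (0.07 log units; within the scatter) lies within the scatter, so the pair cannot be ordered. Compound 3 `CNC(=O)Nc1ccc2cc(C(O)(c3c[nH]cn3)C(C)C)ccc2c1` has not yet been measured in this assay. It differs from compound 2 in one place: (methylcarbamoyl)amino in place of acetyl on an aromatic carbon. Going by the values given here, the one measured step that bears on this position, a 1.2-fold higher number from compound 1 to compound 2 (0.07 log units; within the scatter), exchanged one group on the same aromatic carbon and left the number essentially unchanged. Among the compounds with values here, no measured step covers the entry of the (methylcarbamoyl)amino group itself, so the expectation rests on that single step alone. Compound 3 is therefore expected to give 15 nM, with a range from 6 nM to 40 nM. The expected step of a 1.1-fold higher number from compound 2 to compound 3 (0.03 log units; within the scatter) is thus no larger than the scatter.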

Compound 3, half-maximal inhibitory concentration: 11 nM
Estimate against measurement, compound 3: 1.4-fold (0.13 log units) above; the measured number falls inside the stated range.
By their numbers in this assay, from the lowest: compounds 3, 1 and 2 (each within the scatter of the next).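

With (methylcarbamoyl)amino on this aromatic carbon, this assay gives a 1.3-fold lower number from compound 2 to compound 3 (0.10 log units; within the scatter) and a 1.1-fold lower number from compound 1 to compound 3 (0.04 log units; within the scatter), so all three numbers lie within the scatter of one another. The earlier pair exchanged only groups joined to the ring through a carbonyl carbon, whereas this group is joined through nitrogen, has 5 heavy atoms against 3 in acetyl, and has 2 hydrogen-bond donors against 0 in acetyl, yet the number does not separate from the others. No evidence here explains why these groups give such similar numbers.

The compounds shown leave open whether a plain amine, a carboxylic acid or a longer alkyl chain on this carbon would also stay within the scatter. They also leave open whether this holds on any other core, as all three share one.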